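The compounds below may be only part of what the source reports. "The series", "measured", "known", "first", "only" and "open" are said of these compounds alone.

Values so far in a functional assay on L1210 cells (Mus musculus) for inhibition, with a stated time of 96 h (a lower number here means a stronger inhibitor, a higher number a weaker inhibitor), are these
- compound 1 `CCCNCCCNCCCN` gives 100000 nM
- compound 2 `CCCNCCCNCCCNCCC` gives 60000 nM
- compound 3 `CCCNCCCCNCCCNCCC` gives 33000 nM

Compound 3 stands at 33000 nM and cannot be separated from compound 2 (a 1.8-fold lower number from compound 2 to compound 3 (0.26 log units; within the scatter)). Its gap to compound 1 clears the scatter, but only modestly (a 3.0-fold lower number from compound 1 to compound 3 (0.48 log units; beyond the scatter)).

The next compound, compound 4 (`CCCNCCCCCNCCCCNCCC`), carries one further change (2-(propylamino)ethyl in place of propylamino on a saturated chain carbon, three bonds along the chain from an amine nitrogen). In words, this is 2-(propylamino)ethyl in place of propylamino on a saturated chain carbon, three bonds along the chain from an amine nitrogen.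

For the measured compounds named here, the closest precedent is the exchange in which propylamino also left a saturated chain carbon (a 1.8-fold lower number from compound 2 to compound 3 (0.26 log units; within the scatter)), and that step stayed within the scatter. The step that put propyl in place of hydrogen on an amine nitrogen (a 1.7-fold lower number from compound 1 to compound 2 (0.22 log units; within the scatter)) also stayed within it. Neither gives grounds for expecting a large move, and the data do not show how far the trend, if it is one, extends.

In this assay a small shift toward a lower number is therefore expected, most likely within the scatter. The estimated step is small (a 1.5-fold lower number from compound 3 to compound 4 (0.18 log units; within the scatter)). For compound 4 the estimated value is 22000 nM (expected range 8000 nM to 60000 nM).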

Compound 4, half-maximal inhibitory concentration: 1200 nM
Compound 4: the middle estimate sits 18-fold (1.26 log units) above what was measured; measured number outside the range, below it.
By their numbers in this assay, from the lowest: compound 4; then compounds 3, 2 and 1 (each within the scatter of the next, the first and the last beyond it).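

For the compounds shown here, at this position, in this assay, the exchange of propylamino for 2-(propylamino)ethyl on a saturated chain carbon, three bonds along the chain from an amine nitrogen, gives the first large step (a 28-fold lower number from compound 3 to compound 4 (1.44 log units; beyond the scatter)). The earlier exchange of propylamino for (propylamino)methyl at a saturated chain carbon stayed within the scatter (a 1.8-fold lower number from compound 2 to compound 3 (0.26 log units; within the scatter)), so the response to this kind of change is not evenly graded across the compounds shown: compound 3 resolves from neither neighbour in the way compound 4 resolves from compound 3. No measurement here bears on why the step is this large.

The compounds shown leave open whether a still longer chain at this place, such as 3-(propylamino)propyl, would extend the step, hold it or reverse it. They also leave open whether the step depends on the propyl ends of the chain, which a shorter end group such as ethyl, or a free primary amine in their place, would test.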